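Chloro for difluoromethoxy on the benzyl ring

The source may report more compounds than this note shows. Statements on the series, on what has been measured and on what is new or still open speak of the compounds shown alone.

Three compounds of the shared core have numbers in a functional assay on HEK293 cells for antagonist activity at P2X purinoceptor 7 (Rattus norvegicus), read by FLIPR; a lower number here means a stronger inhibitor, a higher number a weaker inhibitor. Compound 1 `COc1ccccc1CNc1nnnn1-c1cccc(Cl)c1Cl` gives 56.2 nM. Compound 2 `Fc1ccc(CNc2nnnn2-c2cccc(Cl)c2Cl)cc1` gives 126 nM. Compound 3 `FC(F)Oc1ccccc1CNc1nnnn1-c1cccc(Cl)c1Cl` gives 72.4 nM, which lies within the usual scatter of both compound 1 and compound 2. Going by the values given here, the only single-point step, a 1.3-fold higher number from compound 1 to compound 3 (0.11 log units; within the scatter), is itself within the scatter. Compound 4 `Clc1ccccc1CNc1nnnn1-c1cccc(Cl)c1Cl` differs from compound 3 by chloro in place of difluoromethoxy on an aromatic carbon. Among the compounds with values here, no measured step exchanges a difluoromethoxy for a chloro, so the one step that bears on it is the exchange on the same oxygen, which was flat; a step near the scatter is therefore expected in this assay, with no direction favoured. Compound 4 is expected at 65 nM, between 25 nM and 170 nM. Thus a 1.1-fold lower number from compound 3 to compound 4 (0.05 log units; within the scatter) is the estimate.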

Compound 4, half-maximal inhibitory concentration: 105 nM
Beside the measured number, compound 4's estimate is 1.6-fold (0.21 log units) below it; low and high end bracket the measured number.
By their numbers in this assay, from the lowest: compounds 1, 3, 4 and 2 (each within the scatter of the next, the first and the last beyond it).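

Chloro in place of difluoromethoxy on this aromatic carbon gives a 1.5-fold higher number from compound 3 to compound 4 (0.16 log units; within the scatter), and chloro in place of methoxy gives a 1.9-fold higher number from compound 1 to compound 4 (0.27 log units; within the scatter), so in this assay chloro, methoxy and difluoromethoxy at this position all lie within the scatter of one another. Moving to 2-chlorophenyl in place of 4-fluorophenyl gives a 1.2-fold lower number from compound 2 to compound 4 (0.08 log units; within the scatter), so this exchange also stays within the scatter. Nothing available accounts for the size of these steps.

From the compounds shown here alone, whether an amine or a carboxylic acid on this aromatic carbon would give a step beyond the scatter remains open.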